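A few compounds are considered here, and "the series" means these few. Any claim that something is new, unique, unknown or untested is made for them only; others in the source may bear on it.

The series shares one core, shown in compound 1 `O=C(CN(C(=O)C1CCOCC1)C1CCCCC1)Nc1cc(F)cc(F)c1`, compound 2 `O=C(CN(C(=O)C1CCCCC1)C1CCCCC1)Nc1cc(F)cc(F)c1` and compound 3 `O=C(CN(C(=O)c1cccnc1)C1CCCCC1)Nc1cc(F)cc(F)c1`. In a physicochemical assay for lipophilicity (on this read-out lower numbers stand for lower lipophilicity and higher numbers for higher lipophilicity), compound 1 gives 3. For compound 2 the outcome in this assay is "not determined" (no result reported). In this assay compound 3 gives 2.7, the lowest of the two numbers available; its nearest neighbour is compound 1, and the step is a number 0.30 log units lower from compound 1 to compound 3 (within the scatter). Since compound 2 has no number, compound 3 stands against a single neighbour only.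

Compound 4 `Cn1ccc(C(=O)N(CC(=O)Nc2cc(F)cc(F)c2)C2CCCCC2)n1` has not yet been measured in this assay. It differs from compound 3 in one place: 1-methyl-1H-pyrazol-3-yl in place of pyridin-3-yl on a carbonyl carbon. Among the measured compounds shown here, the only measured step that bears on this change sits on the same carbonyl carbon, a number 0.30 log units lower from compound 1 to compound 3 (within the scatter), where oxan-4-yl was exchanged for pyridin-3-yl. That exchange of one ring for another at this position stayed inside the scatter. For the measured compounds named here, no measured step in the set covers the exchange of pyridin-3-yl for 1-methyl-1H-pyrazol-3-yl itself. The step of a number 0.20 log units lower from compound 3 to compound 4 (within the scatter) is therefore expected to stay within the scatter, if anything slightly downward. For compound 4 a value of 2.5 is estimated in this assay, with a range from 2 to 3.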

Compound 4, distribution coefficient: 3
Compound 4: middle estimate off by 0.50 log units, on the low side, within the range that was stated.
By their numbers in this assay, from the lowest: compounds 3, 1 and 4 (each within the scatter of the next).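

In this assay the exchange of pyridin-3-yl for 1-methyl-1H-pyrazol-3-yl on the carbonyl carbon reads as a number 0.30 log units higher from compound 3 to compound 4 (within the scatter), and the exchange of oxan-4-yl for the same group reads as no change at the digits printed from compound 1 to compound 4 (within the scatter). Where the earlier compounds offered a single pair, three different rings at this position now stand within the scatter of one another, and the read-out does not separate a six-membered aromatic ring with 1 hetero atom from a five-membered aromatic ring with 2 hetero atoms. Nothing available explains why these values lie so close together.

Compound 2 gives no number, so it adds no comparison at this position, and all three groups with a number are rings joined directly to the carbonyl carbon. On these data alone, whether a group of another kind at the same place, such as an amine, a carboxylic acid or a longer chain, would give a step beyond the scatter remains open, as does whether the closeness seen among compounds 1, 3 and 4 would hold for any other ring.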